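Chloro for methoxy on the azido nucleoside core

This account rests on a few compounds, and the source may have more. Where it says the series, first, only, none or still open, it means among the compounds named here.

Working notes on an ADME assay on Vero cells (Chlorocebus sabaeus) for cytotoxicity, with a stated time of 5 days; on this read-out higher numbers stand for weaker inhibition and lower numbers for stronger inhibition. Compound 1 (`COc1nc(NC2CC2)c2ncn([C@H]3C[C@H](N=[N+]=[N-])[C@@H](CO)O3)c2n1`) reads > 100000 nM, which is a limit of the assay and not a number. Compound 2 (`CC(C)(CO)Nc1nc(N)nc2c1ncn2[C@H]1C[C@H](N=[N+]=[N-])[C@@H](CO)O1`) reads > 100000 nM, also a limit. Among the compounds with values here, compound 1 and compound 2 therefore stand together at the limit of > 100000 nM in this assay, at which 2 of the 2 values shown sit, so compound 1 cannot be ranked against compound 2, and no measured step is available as a guide.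

Compound 3 (`[N-]=[N+]=N[C@H]1C[C@H](n2cnc3c(NC4CC4)nc(Cl)nc32)O[C@@H]1CO`) keeps the core of compound 1 but carries chloro in place of methoxy on an aromatic carbon, between two ring nitrogen atoms: chloro in place of methoxy on an aromatic carbon. The expected change in this assay is small and, if visible at all, towards stronger inhibition; the estimated at least 1.4-fold lower number from compound 1 to compound 3 (0.15 log units; that floor lies within the scatter) may not exceed the scatter. For compound 3 the expected value is 70000 nM, with an estimated range of 25000 nM to 150000 nM.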

Compound 3, half-maximal inhibitory concentration: > 100000 nM
Compound 3: only a limit was reported; the forecaster's own chance of this, stated with the estimate: 60%; at least 1.4-fold (0.15 log units) between middle value and limit.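

In this assay no step can be read from compound 1 to compound 3, because both stand at the same limit: the limit of > 100000 nM in this assay, at which 3 of the 3 values shown sit.

The compounds shown leave open whether chloro in place of methoxy on an aromatic carbon shifts this read-out at all, and how compounds 1, 2 and 3 rank.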